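The source may report more compounds than this note shows. Statements on the series, on what has been measured and on what is new or still open speak of the compounds shown alone.

Working notes on the series. Two members have numbers in an assay on HEK293 cells for positive allosteric modulation of metabotropic glutamate receptor 3 (Rattus norvegicus), read by thallium flux, with a stated time of 2.5 min; a lower number here means that less compound is needed, a higher number that more compound is needed for the effect. Compound 1 `COc1ccc(C(=O)O)cc1OCCCCOc1ccc(C(=O)C(C)C)c(O)c1C` gives 588 nM in this assay. For the measured compounds named here, compound 2 `Cc1c(OCCCCOc2cccc(C(=O)O)c2)ccc(C(=O)CC(C)C)c1O` gives 1430 nM in this assay, the highest of the two numbers so far; its nearest neighbour is compound 1, and the gap between the two lies beyond the scatter. Going by the values given here, compound 1 and compound 2 differ in more than one place, so no single step between measured compounds can be read off.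

Compound 3 `COc1ccc(C(=O)O)cc1OCCCCOc1ccc(C(=O)CC(C)C)c(O)c1C` is not yet measured. It differs from compound 2 in one place: methoxy in place of hydrogen on an aromatic carbon. Among the compounds with values here, the only guide is that compound 1, which carries a methoxy group, shows the lower number of the two, but compound 1 also differs from compound 2 elsewhere, so the weight of the methoxy group alone is unknown. A modest drop in the number is expected, so the step of a 1.6-fold lower number from compound 2 to compound 3 (0.20 log units; within the scatter) is estimated to lie near the edge of the scatter. Compound 3 is therefore expected at 900 nM, within 400 nM to 2000 nM.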

Compound 3, half-maximal effective concentration: 737 nM
Estimate against measurement, compound 3: 1.2-fold (0.09 log units) above, and the stated range covers the measured number.
By their numbers in this assay, from the lowest: compounds 1, 3 and 2 (each within the scatter of the next, the first and the last beyond it).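

In this assay, for the compounds shown here, methoxy in place of hydrogen on an aromatic carbon, ortho to a large group and para to a carboxy group, gives a 1.9-fold lower number from compound 2 to compound 3 (0.29 log units; within the scatter) and so the first single-place reading at this position stays inside the scatter. The other single-place reading, isobutyl in place of isopropyl on a carbonyl carbon, gives a 1.3-fold higher number from compound 1 to compound 3 (0.10 log units; within the scatter) and so these two side chains cannot be told apart in this assay. No independent data bear on what lies behind either step.

Going by these compounds, whether a different group on that aromatic carbon, such as ethoxy or a fluorine atom, would give a step beyond the scatter remains open. Also open, on these data alone, is how a longer chain or a cyclopropyl ring on the carbonyl carbon would read.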